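Cyano for trifluoromethyl on the distal ring of phenylpropanoic acids

The compounds below may be only part of what the source reports. "The series", "measured", "known", "first", "only" and "open" are said of these compounds alone.

Two phenylpropanoic acids carrying a benzylamino group have been measured in a functional assay for agonist activity at Free fatty acid receptor 1 (Homo sapiens); on this read-out lower numbers stand for an effect already at smaller amounts and higher numbers for an effect only at larger amounts of compound. Compound 1 `O=C(O)CCc1cccc(NCc2ccc(-c3ccccc3)cc2)c1` gives 501 nM in this assay. Compound 2 `O=C(O)CCc1ccc(NCc2ccc(C(F)(F)F)cc2)cc1` gives 2000 nM in this assay. Of the two numbers, compound 2 has the higher one; the gap to compound 1 lies beyond the scatter of repeated measurements, so compound 2 is the weaker of the pair. The two compounds differ in more than one place, so no single change can be read from that gap.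

Compound 3 `N#Cc1ccc(CNc2ccc(CCC(=O)O)cc2)cc1` is not yet measured. It differs from compound 2 in one place: cyano in place of trifluoromethyl on an aromatic carbon. No comparable exchange of a group on that ring has been measured in this series, so the step has to be judged from compound 2 alone. The step from compound 2 to compound 3 is expected to be small, a 1.3-fold higher number from compound 2 to compound 3 (0.10 log units; within the scatter), probably not beyond the scatter, if anything toward a higher number. For compound 3 the expected value in this assay is 2500 nM, with a range from 800 nM to 8000 nM.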

Compound 3, half-maximal effective concentration: < 31700 nM
Compound 3: a limit, no number (the forecaster's own chance of this, stated with the estimate: 10%); the middle value does not contradict the limit.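

For compound 3, this assay returns a limit and not a number, < 31700 nM, so no step can be read between compound 2 and compound 3. The compounds shown leave open whether cyano in place of trifluoromethyl on an aromatic carbon shifts the half-maximal effective concentration at all, and in which direction.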